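The compounds below may be only part of what the source reports. "The series", "measured", "known", "first", "only" and "open" are said of these compounds alone.

Within the data shown here, in a functional assay on HT cells (Homo sapiens) for antiproliferative activity, read by fluorescence, with a stated time of 72 h (on this read-out lower numbers stand for stronger inhibition of growth and higher numbers for weaker inhibition of growth), compound 1 `CC(C)c1n[nH]c2c(NCc3ccc(-c4ccccn4)cc3)nc(SCC(O)CO)nc12` gives 21 nM and compound 2 `CC(C)c1n[nH]c2c(NCc3ccc(-c4ccccn4)cc3)nc(SCCCN(C)C)nc12` gives 105 nM, the higher of the two numbers so far. Compound 3 `CC(C)c1n[nH]c2c(NCc3ccc(-c4ccccn4)cc3)nc(SCC(C)(C)N)nc12` has 1-amino-1-methylethyl in place of 2-(dimethylamino)ethyl on a saturated chain carbon bound to a sulfur. Among the measured compounds shown here, only one measured step bears on this change, the modest 5.0-fold higher number from compound 1 to compound 2 (0.70 log units; beyond the scatter), in which the same carbon's 1,2-dihydroxyethyl gave way to 2-(dimethylamino)ethyl. A similarly modest move toward a lower number is therefore expected, with the estimated step being a 1.8-fold lower number from compound 2 to compound 3 (0.24 log units; within the scatter). The expected value for compound 3 is 60 nM, within an estimated range of 20 nM to 180 nM.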

Compound 3, concentration for 50% growth inhibition: 85 nM
Compound 3: middle estimate off by 1.4-fold (0.15 log units), on the low side; the range from low to high includes it.
By their numbers in this assay, from the lowest: compound 1; then compounds 3 and 2 (each within the scatter of the next).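

In this assay, the change to 1-amino-1-methylethyl from 2-(dimethylamino)ethyl gives a 1.2-fold lower number from compound 2 to compound 3 (0.09 log units; within the scatter) and so does not separate these two amine chains, despite their different shapes on the saturated chain carbon bound to a sulfur. The 1,2-dihydroxyethyl chain stays apart from this second amine chain as well, with a 4.0-fold higher number from compound 1 to compound 3 (0.61 log units; beyond the scatter) as the step. Nothing given here accounts for that gap. Still open, as far as these compounds go, is whether a carboxylic acid, a simple ether or a longer chain at this place would fall nearer compound 1 or compound 3.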